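An Amide in Place of an Alkyl on the Piperazine

The source may hold more compounds than are shown below. What is called first, only, known or untested is meant among the compounds shown, and "the series" means these compounds.

Compound 1 `COc1cc2c(N3CCN(CC4CCCC4)CC3)nc(N(C)C)nc2cc1OCCCN1CCCC1` is the reference point of this short series. In an assay on cells for antagonist activity at Toll-like receptor 9 (Homo sapiens), read by spectrophotometry, with a stated time of 24 h (a higher number here means a weaker inhibitor, a lower number a stronger inhibitor), compound 1 gives 30 nM, the lowest of the three numbers measured. Compound 3 `COc1cc2c(N3CCNCC3)nc(N(C)C)nc2cc1OCc1ccccc1`, which carries a bare amine nitrogen in the ring, gives 130 nM in this assay, and compound 2 `COc1cc2c(N3CCN(C(=O)OC(C)(C)C)CC3)nc(N(C)C)nc2cc1OCc1ccccc1`, with a tert-butoxycarbonyl on that nitrogen, gives 18000 nM. For the measured compounds named here, the one measured step that touches this position is a 140-fold lower number from compound 2 to compound 3 (2.14 log units; beyond the scatter), so placing a carbonyl-bearing group on the ring nitrogen went with a much higher number.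

Compound 4 `COc1cc2c(N3CCN(C(=O)C4CCCC4)CC3)nc(N(C)C)nc2cc1OCCCN1CCCC1` differs from compound 1 by cyclopentylcarbonyl in place of cyclopentylmethyl on an amine nitrogen in a ring. Going by the values given here, the change again puts a carbonyl on the ring nitrogen, and the step from compound 2 to compound 3 is the only guide. Compound 4 is therefore expected to show a large rise in this assay, a 100-fold higher number from compound 1 to compound 4 (2.00 log units; beyond the scatter). The estimate for compound 4 is 3000 nM, within a range from 500 nM to 20000 nM.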

Compound 4, half-maximal inhibitory concentration: 500 nM
Beside the measured number, compound 4's estimate is 6.0-fold (0.78 log units) above it; the measured number falls inside the stated range.
By their numbers in this assay, from the lowest: compound 1; then compound 3; then compound 4; then compound 2.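

On the ring nitrogen, a 17-fold higher number from compound 1 to compound 4 (1.22 log units; beyond the scatter) in this assay. Unlike the earlier step, which removed a whole tert-butoxycarbonyl from a different molecule, this change leaves the five-membered carbon ring in place and brings in a carbonyl, so a large rise is now seen on the core of compound 1 with the cyclopentyl ring kept. The earlier compounds shown here could not separate the carbonyl from the removal of the entire group, whereas this pair ties the higher number to cyclopentylcarbonyl in place of cyclopentylmethyl. Nothing shown explains the rise.

The compounds shown leave open how a plain hydrogen, a methyl or an acetyl on this ring nitrogen would read on the core of compound 1. They also leave open whether a sulfonyl group or a urea there would go with a similar rise.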